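Adding Trifluoromethyl to Two Compounds Held at the Assay Limit

The source may report more compounds than this note shows. Statements on the series, on what has been measured and on what is new or still open speak of the compounds shown alone.

compound 1 `O=Cc1cn(-c2ccccc2)nc1-c1ccc(Cl)cc1`: > 50000 nM
compound 2 `Clc1ccc(-c2nn(-c3ccccc3)cc2-c2nc3ccccc3[nH]2)cc1`: > 50000 nM

In an ADME assay on HaCaT cells (Homo sapiens) for cytotoxicity, read by MTT assay, with a stated time of 48 h (on this read-out higher numbers stand for weaker inhibition and lower numbers for stronger inhibition), compound 1 gives > 50000 nM, which is a limit of the assay. In this assay compound 2 gives > 50000 nM, likewise a limit. The step that the two limits leave unreadable from compound 1 to compound 2 cannot be read, since (the limit of > 50000 nM in this assay, at which 2 of the 2 values shown sit). Within the data shown here, compound 2 therefore stands at the limit, as does the only other value shown. Compound 3 `FC(F)(F)c1ccc2[nH]c(-c3cn(-c4ccccc4)nc3-c3ccc(Cl)cc3)nc2c1` differs from compound 2 by trifluoromethyl in place of hydrogen on an aromatic carbon. No measured step bears on this change, and the one step shown is unreadable, so no direction can be drawn from the data. Compound 3 is expected to give 60000 nM (20000 nM to 200000 nM) in this assay. The expected step is a step that the limit leaves unreadable from compound 2 to compound 3.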

Compound 3, half-maximal inhibitory concentration: 41800 nM
The estimate for compound 3 lay 1.4-fold (0.16 log units) above the measured number; low and high end bracket the measured number.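

In this assay, among these compounds, trifluoromethyl in place of hydrogen on an aromatic carbon of the fused system gives the first value in this set that is a number rather than a limit. The change reads as an at least 1.1-fold lower number from compound 2 to compound 3 (0.07 log units; that floor lies within the scatter). On these data alone, the true size of this step stays unknown, since one of its two ends is a limit: the limit of > 50000 nM in this assay, at which 2 of the 3 values shown sit.

As far as these compounds go, it remains open whether an amine or a carboxylic acid at the same place would also give a number in this assay or stay at the limit.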